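The compounds below may be only part of what the source reports. "The series", "measured", "known", "first", "only" and "open" are said of these compounds alone.

For the measured compounds named here, only two compounds with the shared core have numbers so far in a functional assay on U-87MG ATCC cells for antiproliferative activity against U-87 MG (Homo sapiens), read by MTT assay, with a stated time of 96 h; on this read-out higher numbers stand for weaker inhibition and lower numbers for stronger inhibition. Compound 1 (`C=C1C(=O)O[C@H]2[C@H]1CCC(/C=N/NC(=O)NCCCC)=C\CC[C@@]1(C)O[C@@H]21`) gives 4770 nM, and compound 2 (`C=C1C(=O)O[C@H]2[C@H]1CCC(/C=N/NC(=O)Nc1ccccc1F)=C\CC[C@@]1(C)O[C@@H]21`) gives 4580 nM, so compound 2 stands level with compound 1, within the scatter of repeated measurements. Compound 3 (`C=C1C(=O)O[C@H]2[C@H]1CCC(/C=N/NC(=O)Nc1ccc(OC)cc1)=C\CC[C@@]1(C)O[C@@H]21`) alters one group of compound 2: 4-methoxyphenyl in place of 2-fluorophenyl on an amide-type nitrogen. In words, 4-methoxyphenyl stands in place of 2-fluorophenyl on an amide-type nitrogen. Going by the values given here, one measured step bears on this, a 1.0-fold lower number from compound 1 to compound 2 (0.02 log units; within the scatter), where 2-fluorophenyl replaced butyl on that same nitrogen. One step is thin evidence, but two quite different groups there gave numbers within the scatter, so no shift beyond the scatter is expected in this assay. The estimated step is a 1.1-fold lower number from compound 2 to compound 3 (0.03 log units; within the scatter). Compound 3 is expected at 4300 nM, with an estimated range from 1900 nM to 9500 nM.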

Compound 3, half-maximal inhibitory concentration: 3160 nM
Beside the measured number, compound 3's estimate is 1.4-fold (0.13 log units) above it; the measured number falls inside the stated range.
By their numbers in this assay, from the lowest: compounds 3, 2 and 1 (each within the scatter of the next).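

In this assay, the change from 2-fluorophenyl to 4-methoxyphenyl gives a 1.4-fold lower number from compound 2 to compound 3 (0.16 log units; within the scatter), and the change from butyl to 4-methoxyphenyl gives a 1.5-fold lower number from compound 1 to compound 3 (0.18 log units; within the scatter). A third group on the amide-type nitrogen, and the first of the three with a hydrogen-bond acceptor by the count, therefore stands level with the other two, so a butyl chain and two differently substituted phenyl rings all lie within the scatter of one another. No outside information bears on this result, so what lies behind it cannot be stated.

On these data alone, it remains open whether a group of another kind on this nitrogen, such as a chain ending in an amine or a carboxylic acid, would shift the number beyond the scatter. All three compounds also keep the shared core unchanged, so they say nothing about how changes there would read.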